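Changing the ring on the carbonyl: compound 2 to compound 3

The source may hold more compounds than are shown below. What is called first, only, known or untested is meant among the compounds shown, and "the series" means these compounds.

Compound 2 `O=C(/C=C/c1ccc2c(c1)B(O)OC2)c1ccc(Cl)cc1`: 3700 nM
Compound 1 `O=C(/C=C/c1ccc2c(c1)B(O)OC2)c1ccc(-c2ccccc2)cc1`: 4900 nM

Of the compounds shown here, two have so far been measured in a functional assay on SK-OV-3 cells (Homo sapiens) for cytotoxicity, read by MTT assay, with a stated time of 48 h; on this read-out lower numbers stand for stronger inhibition and higher numbers for weaker inhibition. Compound 1 gives 4900 nM, and compound 2 gives 3700 nM. Compound 2 holds the lowest of the two numbers, but the step of a 1.3-fold lower number from compound 1 to compound 2 (0.12 log units; within the scatter) shows that the two cannot be told apart by this read-out. Compound 3 `Cc1cccc(C(=O)/C=C/c2ccc3c(c2)B(O)OC3)c1` has not yet been measured. It differs from compound 2 at a single place: 3-methylphenyl in place of 4-chlorophenyl on a carbonyl carbon. Within the data shown here, no measured step matches this change directly. Among the measured compounds shown here, the only step available replaces phenyl with chloro on an aromatic carbon, and that step stayed within the scatter, so the two values offer no sign that varying the ring attached to the carbonyl carbon moves the number much. On that basis no step beyond the scatter is expected in either direction. The estimated change is a 1.2-fold higher number from compound 2 to compound 3 (0.09 log units; within the scatter). Compound 3 is therefore expected to give 4500 nM, most likely falling between 1800 nM and 11000 nM.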

Compound 3, half-maximal inhibitory concentration: 2900 nM
Compound 3: the middle estimate sits 1.6-fold (0.19 log units) above what was measured; measured number inside the range.
By their numbers in this assay, from the lowest: compounds 3, 2 and 1 (each within the scatter of the next).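

Within this assay, the step of a 1.3-fold lower number from compound 2 to compound 3 (0.11 log units; within the scatter) is the first to exchange the whole ring group on the carbonyl carbon, where the earlier pair only replaced phenyl with chloro on an aromatic carbon. Compound 3 carries 3-methylphenyl, which has no chlorine, so at this place the chlorine of compound 2 is not required for a value within the scatter of compound 2, and a methyl-bearing ring serves as well on this read-out. No measurement shown here offers any explanation for this flat result.

Both groups in this step are six-membered aromatic rings of carbon only, with no hydrogen-bond donors or acceptors and no net charge, and the step alters the substituent and its ring position together, so the contribution of each remains unresolved. On these data alone, whether the number at this place would hold with a pyridine ring in place of the phenyl ring, or with an amine or a carboxylic acid on that ring, stays open, as does the effect of any change to the chain or to the shared core.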